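Aminoalkyl and benzamido side chains on the shared core

The source may report more compounds than this note shows. Statements on the series, on what has been measured and on what is new or still open speak of the compounds shown alone.

Compound 1 `O=C(NCc1ccc(F)cc1)c1nc(Br)c2cccnc2c1NCc1ccc(F)cc1` gives > 20000 nM in a functional assay on HCT-116 cells (Homo sapiens) for cytotoxicity, read by MTT assay, with a stated time of 72 h (a lower number here means a stronger inhibitor, a higher number a weaker inhibitor), which is a limit of the assay.
Compound 2 `O=C(NCCCNc1c(C(=O)NCc2ccc(F)cc2)nc(Br)c2cccnc12)c1ccccc1` gives > 10000 nM in this assay, again a limit.
Compound 3 `NCCCNc1c(C(=O)NCc2ccc(F)cc2)ncc2cccnc12` gives > 10000 nM in this assay, also a limit.

Compound 2 stands at the limit shared with compound 3 (the limit of > 10000 nM in this assay, at which 2 of the 3 values shown sit), while compound 1 sits at the other limit (the limit of > 20000 nM in this assay, at which 1 of the 3 values shown sits); no number has yet been read for any compound in this series. Compound 4 `NCCCCCCNc1c(C(=O)NCc2ccc(F)cc2)nc(Br)c2cccnc12` carries the change (3-aminopropyl in place of benzamido on a saturated chain carbon, three bonds along the chain from a nitrogen on an aromatic ring). Within the data shown here, the only measured step that touches this region of the molecule is a step that the two limits leave unreadable from compound 1 to compound 2, and it cannot be sized. Compound 3, which carries a 3-aminopropyl chain on the same nitrogen, gives only a limit as well. With every value a limit, no direction can be read for the step to compound 4; the expectation is therefore a step that the limit leaves unreadable from compound 2 to compound 4, that is, nothing beyond the scatter. Compound 4 is estimated at 15000 nM, between 5000 nM and 40000 nM, most likely reported again as a limit.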

Compound 4, half-maximal inhibitory concentration: > 10000 nM
Compound 4 ended at the assay's limit (the forecaster's own chance of this, stated with the estimate: 80%); the middle value does not contradict the limit.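

In this assay compound 4 gives > 10000 nM, again a limit. The steps to compound 4 from compound 1 and from compound 2 therefore cannot be read. The compounds shown leave open whether any of these side chains on the shared core gives a readable number in this assay.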